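Changing the benzyl ring on a weakly cytotoxic amide

The compounds below may be only part of what the source reports. "The series", "measured", "known", "first", "only" and "open" are said of these compounds alone.

In a functional assay on MDA-MB-435 cells (Homo sapiens) for cytotoxicity, read by MTT assay, with a stated time of 72 h (a lower number here means a stronger inhibitor, a higher number a weaker inhibitor), compound 2 `N[C@H]1CC[C@H](Nc2c(C(=O)NCc3ccc(Cl)cc3Cl)nc(Br)c3cccnc23)CC1` gives 5800 nM as its result, and compound 1 `N[C@H]1CC[C@H](Nc2c(C(=O)NCc3ccc(F)cc3)nc(Br)c3cccnc23)CC1` gives 6000 nM as its result. These two numbers sit level with each other, within the scatter of repeated measurements. For compound 3 `COC(=O)c1nc(Br)c2cccnc2c1N[C@H]1CC[C@H](N)CC1` the reading of > 20000 nM is a limit of the assay and not a number.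

Compound 4 `N[C@H]1CC[C@H](Nc2c(C(=O)NCc3cccc(C(F)(F)F)c3)nc(Br)c3cccnc23)CC1` has not yet been measured. The change 3-(trifluoromethyl)phenyl in place of 2,4-dichlorophenyl on a saturated chain carbon bound to an amide-type nitrogen puts 3-(trifluoromethyl)phenyl in place of 2,4-dichlorophenyl on a saturated chain carbon bound to an amide-type nitrogen. The nearest guide is a change at that same place, a 1.0-fold lower number from compound 1 to compound 2 (0.01 log units; within the scatter) which lies within the scatter. For the measured compounds named here, that is only one measured swap of this kind, so it is a thin guide. The larger at least 3.4-fold higher number from compound 2 to compound 3 (0.53 log units; beyond the scatter) comes with methoxy in place of (2,4-dichlorobenzyl)amino on a carbonyl carbon, and compound 4 makes no such change there. No step beyond the scatter is therefore expected in this assay for this swap. The estimated step is a 1.1-fold lower number from compound 2 to compound 4 (0.02 log units; within the scatter) and it is expected to stay small. For compound 4 the expected value is 5500 nM with an estimated range of 2500 nM to 12000 nM as the likely span.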

Compound 4, half-maximal inhibitory concentration: 4200 nM
Compound 4: middle estimate off by 1.3-fold (0.12 log units), on the high side, and the stated range covers the measured number.
By their numbers in this assay, from the lowest: compounds 4, 2 and 1 (each within the scatter of the next). At a limit, above all of these: compound 3.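

In this assay, a third kind of ring at this place on the amide leaves the reading level, with a 1.4-fold lower number from compound 2 to compound 4 (0.14 log units; within the scatter) and a 1.4-fold lower number from compound 1 to compound 4 (0.15 log units; within the scatter) both inside the usual variation between repeat measurements. The earlier pair carried only halogens directly on the ring, as 4-fluorophenyl and 2,4-dichlorophenyl, whereas 3-(trifluoromethyl)phenyl brings 10 heavy atoms in place of the 8 of 2,4-dichlorophenyl and has no chlorine, so this place accepts a clearly different group without a step beyond the scatter. Across compounds 1, 2 and 4, then, no change to the ring has yet separated one amide from another, and nothing measured here offers an explanation for this flat result.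

What the compounds shown leave open is whether a ring carrying a group of another kind, such as an amine or a carboxylic acid, would move the number beyond the scatter in either direction. They also leave open what a longer chain between the amide nitrogen and the ring would do, or an amide with no ring at all on that nitrogen.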